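The compounds below may be only part of what the source reports. "The series", "measured", "known", "first", "only" and "open" are said of these compounds alone.

Compound 3 `Fc1ccccc1Nc1nc2nonc2nc1Nc1cccc(OC(F)(F)F)c1` stands at the lowest number of the three measured in an assay on mitochondria from L6 cells (Rattus norvegicus) for activation, with a stated time of 90 min (a lower number here means that less compound is needed, a higher number that more compound is needed for the effect), where compound 3 gives 600 nM. Compound 1 `Fc1ccccc1Nc1nc2nonc2nc1Nc1ccccc1` gives 2200 nM in this assay, and compound 2 `CCOc1cccc(Nc2nc3nonc3nc2Nc2ccccc2F)c1` gives 2200 nM. The step of a 3.7-fold lower number from compound 1 to compound 3 (0.56 log units; beyond the scatter) and the step of a 3.7-fold lower number from compound 2 to compound 3 (0.56 log units; beyond the scatter) are the only ones beyond the scatter, while the step of no change at the digits printed from compound 1 to compound 2 (within the scatter) shows nothing. Compound 4 `Fc1ccccc1Nc1nc2nonc2nc1Nc1cccc(C(F)(F)F)c1` differs from compound 3 by trifluoromethyl in place of trifluoromethoxy on an aromatic carbon. Within the data shown here, no measured step exchanges these two groups directly. Both steps that reach compound 3, a 3.7-fold lower number from compound 1 to compound 3 (0.56 log units; beyond the scatter) and a 3.7-fold lower number from compound 2 to compound 3 (0.56 log units; beyond the scatter), end at a fluorinated group in this place, and compound 4 keeps a fluorinated group there, so the step of no change at the digits printed from compound 3 to compound 4 (within the scatter) is expected to stay within the scatter, with no clear direction. For compound 4 the expected value in this assay is therefore 600 nM, with a range from 250 nM to 1500 nM.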

Compound 4, half-maximal effective concentration: < 1000 nM
Compound 4 was reported as a limit (the forecaster's own chance of this, stated with the estimate: 5%); the middle value is on the limit's open side.
By their numbers in this assay, from the lowest: compound 3; then compounds 1 and 2 (each within the scatter of the next).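

In this assay compound 4 is reported only as a limit, not as a number: the limit of < 1000 nM in this assay, at which 1 of the 4 values shown sits.

Even so, two steps can be read, an at least 2.2-fold lower number from compound 1 to compound 4 (0.34 log units; beyond the scatter) and an at least 2.2-fold lower number from compound 2 to compound 4 (0.34 log units; beyond the scatter), so trifluoromethyl joins trifluoromethoxy as a second group at this place that gives a lower number than hydrogen or ethoxy. The step between compound 3 and compound 4 cannot be read, so the two fluorinated groups cannot be ranked against each other.

Among the compounds shown, this place holds only hydrogen, ethoxy, trifluoromethoxy and trifluoromethyl, so it remains open whether the lower number is tied to fluorine in the group. A nitrile, an amine or a carboxylic acid at this place would bear on that question.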